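The compounds below may be only part of what the source reports. "The series", "measured", "known", "first", "only" and "open" are said of these compounds alone.

In a functional assay on HUVEC cells (Homo sapiens) for inhibition, with a stated time of 4 days (a lower number here means a stronger inhibitor, a higher number a weaker inhibitor), compound 1 `COc1ccc(C(C)=O)cc1COc1ccc(Cl)cc1` gives 1200 nM, the lower of the two actual numbers available. Compound 2 `Cc1cc(OCc2cccc(C#N)c2)ccc1Cl` gives 11000 nM, and the gap between the two lies beyond the usual scatter. Compound 3 `COc1ccc(C(=O)O)cc1COc1ccc(Cl)c(C)c1` is recorded only as a limit of the assay, > 50000 nM. This compound differs from compound 1 in more than one place, but it also carries something other than methyl on a carbonyl carbon.

The next compound, compound 4 `COc1ccc(C(N)=O)cc1COc1ccc(Cl)cc1`, stays close to compound 1, and the change is a single one, acetyl to carbamoyl: amino in place of methyl on a carbonyl carbon. Among the measured compounds shown here, no pair of measured compounds differs in just one place, so the size of this step in this assay cannot be read directly from the series. The expectation is a moderate weakening, with a higher number that probably lies beyond the scatter, starting from the 1200 nM of compound 1. The expected number is also expected to remain well short of the limit seen for compound 3. The estimated change is a 2.9-fold higher number from compound 1 to compound 4 (0.46 log units; beyond the scatter). For compound 4 the expected value is 3500 nM, with an estimated range from 900 nM to 15000 nM.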

Compound 4, half-maximal inhibitory concentration: 660 nM
Estimate against measurement, compound 4: 5.3-fold (0.72 log units) above; the whole stated range lies above it.
By their numbers in this assay, from the lowest: compounds 4 and 1 (each within the scatter of the next); then compound 2. At a limit, above all of these: compound 3.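

Amino in place of methyl on a carbonyl carbon gives a 1.8-fold lower number from compound 1 to compound 4 (0.26 log units; within the scatter) in this assay, and this is the first single change that can be read in the series, as no two earlier compounds differed in just one place. At this position, on a carbonyl carbon whose other neighbour is an aromatic carbon, compound 1 and compound 4 therefore cannot be told apart in this assay. The exchange adds the one hydrogen-bond donor counted for amino, and the number stays within the scatter, so the position tolerates this replacement of methyl on the core of compound 1.

From the compounds shown here alone, how methylamino or dimethylamino would read in place of amino on this carbonyl carbon stays open, and so does the effect of a carboxylic acid there on the otherwise unchanged core of compound 1. Compound 3 carries a carboxylic acid but differs from compound 1 in more than one place, and it gives only a limit of the assay, not a number: the limit of > 50000 nM in this assay, at which 1 of the 4 values shown sits.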